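The source may hold more compounds than are shown below. What is called first, only, known or untested is meant among the compounds shown, and "the series" means these compounds.

Among the measured compounds shown here, compound 2 `CCCCOc1ccc2c(Cl)ccnc2c1` gives 3780 nM in a functional assay on DLD-1 cells (Homo sapiens) for cytotoxicity, read by MTT assay, with a stated time of 48 h (on this read-out higher numbers stand for weaker inhibition and lower numbers for stronger inhibition), the upper of the two numbers so far, though with compound 1 `CC(C)COc1ccc2c(Cl)ccnc2c1` at 3100 nM the step of a 1.2-fold higher number from compound 1 to compound 2 (0.09 log units; within the scatter) is within the scatter. Compound 3 `Clc1ccnc2cc(OCCCc3ccccc3)ccc12` differs from compound 2 by phenyl in place of methyl on a saturated chain carbon, three bonds along the chain from an oxygen on an aromatic ring. For the measured compounds named here, the single measured step, a 1.2-fold higher number from compound 1 to compound 2 (0.09 log units; within the scatter), changed only the branching of the chain and gives no reading on a phenyl entering in place of methyl; the expected step is therefore a 1.5-fold lower number from compound 2 to compound 3 (0.18 log units; within the scatter), nothing beyond the scatter. Compound 3 is estimated at 2500 nM, with a range from 800 nM to 8000 nM.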

Compound 3, half-maximal inhibitory concentration: 2140 nM
The estimate for compound 3 lay 1.2-fold (0.07 log units) above the measured number; low and high end bracket the measured number.
By their numbers in this assay, from the lowest: compounds 3, 1 and 2 (each within the scatter of the next).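

Phenyl in place of methyl, on a saturated chain carbon three bonds along the chain from an oxygen on an aromatic ring, gives a 1.8-fold lower number from compound 2 to compound 3 (0.25 log units; within the scatter) in this assay. This position therefore accepts a six-membered aromatic ring of carbon only without a step beyond the scatter, which the branching change alone could not show. No available measurement bears on a cause for this result.

Going by these compounds, whether an amine or a carboxylic acid in place of the phenyl would give a step beyond the scatter remains open. The same question stands for a longer chain carrying the phenyl.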